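Dropping 1,3-thiazol-2-yl from a sulfonamide nitrogen

The compounds below may be only part of what the source reports. "The series", "measured", "known", "first", "only" and "open" are said of these compounds alone.

In a functional assay on COLO 205 cells (Homo sapiens) for antiproliferative activity, read by sulforhodamine B assay, with a stated time of 72 h (a higher number here means a weaker inhibitor, a lower number a stronger inhibitor), compound 1 `O=S(=O)(Nc1nccs1)c1ccc(Nc2nncc3ccccc23)cc1` gives 56 nM and compound 2 `O=C1CS/C(=N/Nc2nncc3ccccc23)N1` gives 55 nM, so these two values lie within the usual scatter of each other. Compound 3 `NS(=O)(=O)c1ccc(Nc2nncc3ccccc23)cc1` has not yet been measured. It differs from compound 1 by hydrogen in place of 1,3-thiazol-2-yl on a sulfonamide nitrogen, with hydrogen in place of 1,3-thiazol-2-yl on a sulfonamide nitrogen. Among the compounds with values here, no measured pair of compounds shows what this change does, so only a moderate weakening in this assay is expected, and this expectation is loose. The expected change is a 2.1-fold higher number from compound 1 to compound 3 (0.33 log units; beyond the scatter). For compound 3 the estimated value is 120 nM, with an expected range of 25 nM to 600 nM.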

Compound 3, half-maximal inhibitory concentration: 23 nM
Estimate against measurement, compound 3: 5.2-fold (0.72 log units) above, and the stated range ends above it.
By their numbers in this assay, from the lowest: compound 3; then compounds 2 and 1 (each within the scatter of the next).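

At the sulfonamide nitrogen, the 1,3-thiazol-2-yl group proves dispensable in this assay and its loss brings a 2.4-fold lower number from compound 1 to compound 3 (0.39 log units; beyond the scatter) rather than any weakening. The plain amino group is therefore enough here, with no heavy atom needed on that nitrogen to reach this level of activity. Nothing available explains this step. On these data alone, whether a methyl group on that nitrogen would keep this level, or a phenyl ring would match 1,3-thiazol-2-yl, remains open. This single step also cannot show whether the same change would hold on another core.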